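From a Pyridinyl Arm to a Dichlorophenyl Arm

A few compounds are considered here, and "the series" means these few. Any claim that something is new, unique, unknown or untested is made for them only; others in the source may bear on it.

Of the compounds shown here, two have been measured in a functional assay on HEK293 cells for agonist activity at G-protein coupled receptor 39 (Homo sapiens), read by inositol phosphate accumulation; a lower number here means that less compound is needed, a higher number that more compound is needed for the effect. Compound 1 `Cc1nc(NCc2ccc(Cl)cc2)cc(-c2ccccn2)n1` gives 81 nM. Compound 2 `CNc1nc(NCc2ccncc2)cc(-c2ccccn2)n1` gives 87 nM, the highest of the two numbers, yet its gap to compound 1 lies within the scatter, so the two cannot be ranked. Compound 3 `CNc1nc(NCc2ccc(Cl)cc2Cl)cc(-c2ccccn2)n1` keeps the core of compound 2 and differs in one place: 2,4-dichlorophenyl in place of pyridin-4-yl on a saturated chain carbon bound to a nitrogen on an aromatic ring. For the measured compounds named here, no measured pair shows this change. Because compound 2 gives 87 nM, compound 3 is expected to land near that level. The expected step of a 1.7-fold lower number from compound 2 to compound 3 (0.24 log units; within the scatter) is small and, if anything, toward a lower number. Compound 3 is estimated at 50 nM, within 15 nM to 200 nM.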

Compound 3, half-maximal effective concentration: 0.8 nM
For compound 3 the middle estimate is 63-fold (1.80 log units) above the measured one; measured number outside the range, below it.
By their numbers in this assay, from the lowest: compound 3; then compounds 1 and 2 (each within the scatter of the next).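

Swapping pyridin-4-yl for 2,4-dichlorophenyl on a saturated chain carbon bound to a nitrogen on an aromatic ring gives a 110-fold lower number from compound 2 to compound 3 (2.04 log units; beyond the scatter), so the group at this position can strongly change how much compound is needed. Compounds 1 and 2 differ in more than one place and could not show this. Nothing available explains the size of this step.

Still open, from the compounds shown here alone, is whether both chlorines are needed on the core of compound 3. Methoxy or trifluoromethyl groups in their place remain untested in the compounds shown.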